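The source may report more compounds than this note shows. Statements on the series, on what has been measured and on what is new or still open speak of the compounds shown alone.

The series shares one core and varies the group that sits on a saturated chain carbon bound to an oxygen on an aromatic ring. Compound 1 `CCOC(=O)c1cc(-c2cccc(OCc3cccc(C#N)c3)c2)on1` carries a 3-cyanophenyl there. In an ADME assay on Vero cells (Chlorocebus sabaeus) for cytotoxicity, with a stated time of 72 h (a higher number here means a weaker inhibitor, a lower number a stronger inhibitor), compound 1 gives only a limit, > 128000 nM, and no number. Among the measured compounds shown here, this is the position described by the limit of > 128000 nM in this assay, at which 1 of the 3 values shown sits, so compound 1 is the sole entry with any value at all. Compound 2 `CCOC(=O)c1cc(-c2cccc(OCc3ccc(F)cc3)c2)on1` has no result in this assay and stands at "not determined" (no result reported). Compound 3 `CCOC(=O)c1cc(-c2cccc(OCc3ccc(Cl)c(Cl)c3)c2)on1` likewise stands at "not determined" (no result reported) in this assay. For the measured compounds named here, no step between two measured compounds can therefore be read off; compound 1 alone anchors the series.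

Compound 4 `CCOC(=O)c1cc(-c2cccc(OCc3c(F)cccc3F)c2)on1` is the next entry. It differs from compound 1 by 2,6-difluorophenyl in place of 3-cyanophenyl on a saturated chain carbon bound to an oxygen on an aromatic ring. Going by the values given here, because compound 1 sits at the limit of > 128000 nM in this assay, at which 1 of the 3 values shown sits, there is no measured step on which to size a shift for this change, and no direction can be drawn from the data. The step of a number no higher from compound 1 to compound 4 (the limit leaves the size open) is therefore expected to be none beyond the scatter. For compound 4 the estimate in this assay is 128000 nM, with a range from 60000 nM to 300000 nM, and with a high chance that this assay again returns only a limit rather than a number.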

Compound 4, half-maximal inhibitory concentration: > 128000 nM
Compound 4: no number, only a limit (the forecaster's own chance of this, stated with the estimate: 80%); the middle value sits exactly at the limit.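

In this assay compound 4 gives > 128000 nM, a limit and not a number. Among the compounds shown here, compound 1 likewise gives only a limit, and no step between compound 1 and compound 4 can be read. The compounds shown leave open whether any group on the saturated chain carbon bound to an oxygen on an aromatic ring yields a number in this assay: the limit of > 128000 nM in this assay, at which 2 of the 4 values shown sit.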